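Swapping the Aryl Group on a Triazole Amide

The source may hold more compounds than are shown below. What is called first, only, known or untested is meant among the compounds shown, and "the series" means these compounds.

Of the compounds shown here, three sharing one core have been tested in a functional assay on HT-29 cells (Homo sapiens) for cytotoxicity, read by MTT assay, with a stated time of 72 h; on this read-out lower numbers stand for stronger inhibition and higher numbers for weaker inhibition. Compound 2 `O=C(Nc1ccc(Oc2ccnc3[nH]ccc23)cc1)c1nnn(-c2ccc(F)cc2)c1C(F)(F)F` gives 93 nM, compound 3 `O=C(Nc1ccc(Oc2ccnc3[nH]ccc23)cc1)c1nnn(-c2ccc(F)c(Cl)c2)c1C(F)(F)F` gives 1020 nM, and compound 1 `Cc1c(C(=O)Nc2ccc(Oc3ccnc4[nH]ccc34)cc2)nnn1-c1ccc(Cl)c(C(F)(F)F)c1` gives 3290 nM. Compound 3 therefore stands second highest of the three numbers in this assay, between compound 2 and compound 1.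

Among the compounds with values here, the only single change measured so far is the one from compound 2 to compound 3, where a chloro replaces a hydrogen on an aromatic carbon; this gave an 11-fold higher number from compound 2 to compound 3 (1.04 log units; beyond the scatter).

Compound 4 `O=C(Nc1ccc(Oc2ccnc3[nH]ccc23)cc1)c1nnn(-c2ccc(Cl)c(C(F)(F)F)c2)c1C(F)(F)F` is not yet measured. It differs from compound 3 by 4-chloro-3-(trifluoromethyl)phenyl in place of 3-chloro-4-fluorophenyl on an aromatic nitrogen. The entering group is the same aryl group that compound 1 carries, but compound 1 also differs in a second place, so its number of 3290 nM can only be read alongside, not as a clean step.

Within the data shown here, the one measured step that bears on this, from compound 2 to compound 3, was large and went towards a higher number. Compound 4 is thus expected to stay in the weaker region, with an estimated step of a 1.5-fold higher number from compound 3 to compound 4 (0.17 log units; within the scatter) in this assay. For compound 4 the estimate is 1500 nM, with a range from 400 nM to 6000 nM.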

Compound 4, half-maximal inhibitory concentration: 1530 nM
For compound 4 the middle estimate is 1.0-fold (0.01 log units) below the measured one; measured number inside the range.
By their numbers in this assay, from the lowest: compound 2; then compounds 3 and 4 (each within the scatter of the next); then compound 1.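

In this assay, putting 4-chloro-3-(trifluoromethyl)phenyl in place of 3-chloro-4-fluorophenyl on the aromatic nitrogen gives a 1.5-fold higher number from compound 3 to compound 4 (0.18 log units; within the scatter), so these two aryl groups cannot be told apart on this read-out. Set against the 4-fluorophenyl group, the same entering group gives a 16-fold higher number from compound 2 to compound 4 (1.22 log units; beyond the scatter), which means that among the three aryl groups carried with a trifluoromethyl group on the neighbouring ring atom, only the 4-fluorophenyl group stands apart, and both chlorine-bearing groups sit on the weaker side. Within the data shown here, compound 4 also isolates the group on the aromatic carbon for the first time: with the aryl group held fixed, trifluoromethyl in place of methyl gives a 2.2-fold lower number from compound 1 to compound 4 (0.33 log units; beyond the scatter), a modest step towards stronger inhibition. Nothing measured here accounts for the size of these steps.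

The compounds shown leave open whether the trifluoromethyl-for-methyl step would have the same size with the 4-fluorophenyl group on the nitrogen. They also leave open how an aryl group carrying an amine or a carboxylic acid, or a plain cyclohexyl ring, would fare on that nitrogen.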